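The compounds below may be only part of what the source reports. "The series", "measured", "known", "first", "only" and "open" are said of these compounds alone.

Measured so far in a functional assay on HCT-116 cells (Homo sapiens) for antiproliferative activity, read by MTT assay, with a stated time of 24 h; on this read-out lower numbers stand for stronger inhibition and higher numbers for weaker inhibition:
- Compound 1 `COc1ccc(/C=C/C(=O)c2ccc(OC)c3c2OC(C)(C)C=C3)c(F)c1`: > 10000 nM, a limit
- Compound 2 `COc1ccc(C(=O)/C=C/c2ccc(O)cc2)c2c1C=CC(C)(C)O2`: > 10000 nM, a limit

Compound 2 has no actual number here, only the limit > 10000 nM. The evidence so far is the limit of > 10000 nM in this assay, at which 2 of the 2 values shown sit. For the measured compounds named here, the one measured step, a step that the two limits leave unreadable from compound 1 to compound 2, changes the group at the same place as the next change, but it gives no size to build on.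

Compound 3 `COc1ccc(C(=O)/C=C/c2cc(Cl)ccc2O)c2c1C=CC(C)(C)O2` has not yet been measured. It differs from compound 2 by one swap: 5-chloro-2-hydroxyphenyl in place of 4-hydroxyphenyl on a double-bonded chain carbon bound to a double-bonded chain carbon. Going by the values given here, with only a step that the two limits leave unreadable from compound 1 to compound 2 as a guide, no step of known size or direction can be expected in this assay, and compound 3 is expected to stay close to the limit, perhaps again giving no number. The estimated change is a step that the limit leaves unreadable from compound 2 to compound 3. For compound 3 the estimated value is 12000 nM, with an expected range of 3000 nM to 40000 nM.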

Compound 3, half-maximal inhibitory concentration: 5240 nM
Compound 3: the middle estimate sits 2.3-fold (0.36 log units) above what was measured; the measured number falls inside the stated range.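

In this assay, compound 3, with 5-chloro-2-hydroxyphenyl on a double-bonded chain carbon bound to a double-bonded chain carbon, is the first compound shown to give an actual number rather than a limit, and this swap gives an at least 1.9-fold lower number from compound 2 to compound 3 (0.28 log units; that floor lies within the scatter). Against the 2-fluoro-4-methoxyphenyl group the result is an at least 1.9-fold lower number from compound 1 to compound 3 (0.28 log units; that floor lies within the scatter); both steps are only floors, so their true size stays unknown, and the step between the two compounds held at the limit cannot be read. The limit still marks most of this small set: the limit of > 10000 nM in this assay, at which 2 of the 3 values shown sit.

The compounds shown leave open whether the chlorine or the changed place of the hydroxy group accounts for the step, as this swap alters both at once. They also leave open whether a bromine or an amine in place of that chlorine would give a measurable number too.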